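A few compounds are considered here, and "the series" means these few. Any claim that something is new, unique, unknown or untested is made for them only; others in the source may bear on it.

Measured so far:
compound 1 `CCCSc1nc(N/N=C/c2cccnc2)c2nnn(Cc3ccccc3)c2n1` — 58700 nM
compound 2 `CCCSc1nc(N/N=C/c2cccc(Cl)c2)c2nnn(Cc3ccccc3)c2n1` — > 64000 nM

Compound 1 carries a pyridin-3-yl group on a carbon with a double bond to nitrogen, and in a functional assay on MCF7 cells (Homo sapiens) for antiproliferative activity, read by MTT assay, with a stated time of 72 h (on this read-out lower numbers stand for stronger inhibition and higher numbers for weaker inhibition), compound 1 gives 58700 nM. Compound 2 carries a 3-chlorophenyl group in that place. In this assay compound 2 reaches only a limit of the assay, > 64000 nM, so no number is known for it. The step of an at least 1.0-fold higher number from compound 1 to compound 2 (0.03 log units; that floor lies within the scatter) is therefore bounded from one side only, and the limit of > 64000 nM in this assay, at which 1 of the 2 values shown sits, is where compound 2 sits.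

Compound 3 `CCCSc1nc(N/N=C/c2ccccc2F)c2nnn(Cc3ccccc3)c2n1` differs from compound 2 by 2-fluorophenyl in place of 3-chlorophenyl on a carbon with a double bond to nitrogen. For the measured compounds named here, the only measured step that bears on this change is an at least 1.0-fold higher number from compound 1 to compound 2 (0.03 log units; that floor lies within the scatter), in which exchanging the aryl group on that same carbon left the result at the edge of measurement and gave no resolvable direction. Nothing beyond the scatter is therefore expected from this second exchange of aryl group. The expected step is a number no higher from compound 2 to compound 3 (the limit leaves the size open), meaning no change beyond the scatter. Compound 3 is estimated at 64000 nM, with a range from 35000 nM to 120000 nM, and a fair chance that this assay again reports only a limit.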

Compound 3, half-maximal inhibitory concentration: > 64000 nM
Compound 3 was reported as a limit; the forecaster's own chance of this, stated with the estimate: 55%; the middle value lies on the limit itself.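

In this assay, compound 3 is reported only as a limit, the same outcome as for compound 2, so two different substituted phenyl groups on this carbon now end at the same edge of measurement: the limit of > 64000 nM in this assay, at which 2 of the 3 values shown sit.

The step from compound 2 to compound 3 cannot be read, and the exchange of 3-chlorophenyl for 2-fluorophenyl therefore has no size that can be stated. For the compounds shown here, the one comparison that involves a real number gives an at least 1.0-fold higher number from compound 1 to compound 3 (0.03 log units; that floor lies within the scatter), so no difference beyond the scatter can be claimed between the pyridin-3-yl group and the 2-fluorophenyl group in this place.

The compounds shown leave open whether any group on this carbon can bring the result well clear of the limit, for example a phenyl ring carrying an amine or a carboxylic acid. They also leave open whether a change elsewhere on the shared core, such as a longer chain on the sulfur in place of the propyl chain, would give a measurable number for these aryl groups.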